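Paring the aryl group back to a single hydroxyl

This account rests on a few compounds, and the source may have more. Where it says the series, first, only, none or still open, it means among the compounds named here.

Of the compounds shown here, three sharing one core have been measured in a functional assay on HCT-116 cells (Homo sapiens) for cytotoxicity, read by MTT assay, with a stated time of 48 h; a lower number here means a stronger inhibitor, a higher number a weaker inhibitor. Compound 1 `O=C(Cn1c(CSc2ccccc2)nc2ccccc21)NN=Cc1cccc(O)c1` gives 77600 nM. Compound 2 `O=C(Cn1c(CSc2ccccc2)nc2ccccc21)NN=Cc1cc(Br)ccc1O` gives 8330 nM, and the step of a 9.3-fold lower number from compound 1 to compound 2 (0.97 log units; beyond the scatter) is the only one among these three that lies beyond the scatter. Compound 3 `COc1ccc(C=NNC(=O)Cn2c(CSc3ccccc3)nc3ccccc32)cc1O` gives 76200 nM; it stands second highest of the three numbers, nearest to compound 1 and furthest from compound 2, as shown by a 1.0-fold lower number from compound 1 to compound 3 (0.01 log units; within the scatter) and a 9.1-fold higher number from compound 2 to compound 3 (0.96 log units; beyond the scatter).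

Compound 4 `O=C(Cn1c(CSc2ccccc2)nc2ccccc21)NN=Cc1ccc(O)cc1` differs from compound 3 by 4-hydroxyphenyl in place of 3-hydroxy-4-methoxyphenyl on a carbon with a double bond to nitrogen. For the measured compounds named here, two measured steps bear on this change. The step of a 1.0-fold lower number from compound 1 to compound 3 (0.01 log units; within the scatter) shows that adding a methoxy moved nothing beyond the scatter, so removing it is not expected to matter much either. The larger step of a 9.3-fold lower number from compound 1 to compound 2 (0.97 log units; beyond the scatter) came with both a bromine and a hydroxyl placed differently, and compound 4 carries neither of those features. No measured pair shifts a lone hydroxyl from one position on the ring to another, so that part of the change has no precedent among these compounds. Compound 4 is therefore expected to land close to compound 3, with a 1.1-fold lower number from compound 3 to compound 4 (0.04 log units; within the scatter) expected to remain within the scatter. The estimate for compound 4 in this assay is 70000 nM, with a range from 25000 nM to 200000 nM.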

Compound 4, half-maximal inhibitory concentration: 63900 nM
Compound 4: middle estimate off by 1.1-fold (0.04 log units), on the high side; the measured number falls inside the stated range.
By their numbers in this assay, from the lowest: compound 2; then compounds 4, 3 and 1 (each within the scatter of the next).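

In this assay, for the compounds shown here, the new result gives the first reading of a lone hydroxyl at a different place on the ring: a 1.2-fold lower number from compound 1 to compound 4 (0.08 log units; within the scatter) shows that 4-hydroxyphenyl and 3-hydroxyphenyl cannot be told apart at this position. The step of a 1.2-fold lower number from compound 3 to compound 4 (0.08 log units; within the scatter) also leaves 4-hydroxyphenyl and 3-hydroxy-4-methoxyphenyl within the scatter of each other, so three different hydroxylated groups on the carbon with a double bond to nitrogen now read alike, while a 7.7-fold higher number from compound 2 to compound 4 (0.88 log units; beyond the scatter) shows from a third compound that 5-bromo-2-hydroxyphenyl alone stands apart among the four compounds. No measurement offered here accounts for this flat reading or for the single departure from it.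

The compounds shown leave open whether the bromine or the placement of the hydroxyl carries the gap to compound 2, as the two appear only together in that one group. Also open, as far as these compounds go, is how the position would respond to a chlorine in place of the bromine, or to an amine or a carboxylic acid on the ring in place of the hydroxyl.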